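The source may hold more compounds than are shown below. What is called first, only, known or untested is meant among the compounds shown, and "the series" means these compounds.

Working notes on the series.

The shared core is carried unchanged through compounds 1 to 3; only the amine on the saturated chain carbon bound to an aromatic carbon is varied. Compound 1 `COc1ccc(/C=C\c2cc(OC)c(OC)c(OC)c2)cc1OCc1ccc(CN2C[C@H](O)C[C@@H]2C(=O)O)cc1` gives a limit rather than a number in a functional assay on MC-38 cells (Mus musculus) for antiproliferative activity, read by CCK-8 assay, with a stated time of 48 h; a lower number here means a stronger inhibitor, a higher number a weaker inhibitor: > 10000 nM, which is the limit of the assay (the limit of > 10000 nM in this assay, at which 1 of the 3 values shown sits). Compound 2 `COc1ccc(/C=C\c2cc(OC)c(OC)c(OC)c2)cc1OCc1ccc(CN2CCCCC2C(=O)O)cc1` gives 5400 nM in this assay, and compound 3 `COc1ccc(/C=C\c2cc(OC)c(OC)c(OC)c2)cc1OCc1ccc(CN2CC[C@@H](C(=O)O)C2)cc1` gives 6300 nM. The two measured steps out of compound 1 are an at least 1.8-fold lower number from compound 1 to compound 2 (0.26 log units; that floor lies within the scatter) and an at least 1.5-fold lower number from compound 1 to compound 3 (0.20 log units; that floor lies within the scatter); between the two numbers the step is a 1.2-fold higher number from compound 2 to compound 3 (0.07 log units; within the scatter). Within the data shown here, compound 2 thus gives one of only two numbers, and the gap to compound 3 lies within the scatter, so no order between them can be read.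

Compound 4 `COc1ccc(/C=C\c2cc(OC)c(OC)c(OC)c2)cc1OCc1ccc(CNCCN(C)C)cc1` changes the same position: (2-(dimethylamino)ethyl)amino in place of 2-carboxypiperidin-1-yl on a saturated chain carbon bound to an aromatic carbon. Every measured step here swapped one carboxy-bearing cyclic amine for another, and none moved beyond the scatter; none removed the carboxylic acid or opened the ring, so they bear on this step only loosely. A step of moderate size in either direction is expected, and the estimate for compound 4 in this assay is 3500 nM, within 900 nM to 12000 nM, meaning an expected step of a 1.5-fold lower number from compound 2 to compound 4 (0.19 log units; within the scatter).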

Compound 4, half-maximal inhibitory concentration: 1400 nM
For compound 4 the middle estimate is 2.5-fold (0.40 log units) above the measured one; measured number inside the range.
By their numbers in this assay, from the lowest: compound 4; then compounds 2 and 3 (each within the scatter of the next). At a limit, above all of these: compound 1.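

In this assay, among these compounds, (2-(dimethylamino)ethyl)amino in place of a carboxy-bearing cyclic amine gives the first steps at this position that lie beyond the scatter (a 3.9-fold lower number from compound 2 to compound 4 (0.59 log units; beyond the scatter); a 4.5-fold lower number from compound 3 to compound 4 (0.65 log units; beyond the scatter)). The position therefore does respond to the amine on the saturated chain carbon bound to an aromatic carbon, and a change that removes both the ring and the carboxylic acid separates compound 4 from the carboxy-bearing compounds, where swapping one cyclic amine for another had shown no step beyond the scatter. The third step (an at least 7.1-fold lower number from compound 1 to compound 4 (0.85 log units; beyond the scatter)) is only a floor, as it starts from a limit rather than a number: the limit of > 10000 nM in this assay, at which 1 of the 4 values shown sits.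

Since the ring, the carboxylic acid and the second amine all change in the same step, the compounds shown leave open which of these accounts for the lower number in this assay. A piperidin-1-yl group without the carboxylic acid, an open chain ending in a carboxylic acid, or a longer chain such as (3-(dimethylamino)propyl)amino would begin to separate these contributions.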